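This account rests on a few compounds, and the source may have more. Where it says the series, first, only, none or still open, it means among the compounds named here.

Within the data shown here, compound 1 `CCNC(=O)C1=CC(C)(C)Oc2ccc([N+](=O)[O-])cc21` is one of two compounds measured in a functional assay on the whole organism (muscle tissue) with Rattus norvegicus as the target; on this read-out lower numbers stand for smaller maximal responses and higher numbers for larger maximal responses. In this assay, among the measured compounds shown here, compound 1 gives 80.5%, and the only other compound, compound 2 `C#CCNC(=O)C1=CC(C)(C)Oc2ccc([N+](=O)[O-])cc21`, gives 80.2%; the step of a number 0.3 percentage points lower from compound 1 to compound 2 (within the scatter) stays within the scatter, so the two numbers cannot be told apart, and compound 1 simply sits at the top of a pair that is, in effect, level.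

Compound 3 `CC1(C)C=C(C(=O)NCCC#N)c2cc([N+](=O)[O-])ccc2O1` has not been measured yet. It differs from compound 1 by cyano in place of hydrogen on a saturated chain carbon, two bonds along the chain from an amide-type nitrogen. For the measured compounds named here, the one step on record, from compound 1 to compound 2, also alters the chain on the amide-type nitrogen, putting a triple bond into it, and it moved the response by a number 0.3 percentage points lower from compound 1 to compound 2 (within the scatter), that is, not at all beyond the scatter. On that single precedent no movement beyond the scatter is expected here either, so compound 3 is estimated at 78%, between 65% and 90%, which means an expected step of a number 2.5 percentage points lower from compound 1 to compound 3 (within the scatter).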

Compound 3, intrinsic activity: the largest response reached, in percent of the reference agonist's: 73.1%
Compound 3: middle estimate off by 4.9 percentage points, on the high side, and the stated range covers the measured number.
By their numbers in this assay, from the lowest: compounds 3, 2 and 1 (each within the scatter of the next).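

In this assay, going from ethyl to 2-cyanoethyl on the amide-type nitrogen gives a number 7.4 percentage points lower from compound 1 to compound 3 (within the scatter), and the swap of the ethynyl end for a cyano end gives a number 7.1 percentage points lower from compound 2 to compound 3 (within the scatter). Both steps stay within the scatter, so this chain has now accepted a nitrile as well as a triple bond between carbons, with all three compounds still not separable on maximal response. No available data bear on what lies behind these numbers.

On these data alone, whether an amine or a carboxylic acid at the end of this chain, or a longer chain, would also stay within the scatter of compound 1 remains open. So does the wider question of whether any group placed on this chain can move the response beyond the scatter at all.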